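A Third Fluorine on the Aryl Group: Expecting No Change

The source may report more compounds than this note shows. Statements on the series, on what has been measured and on what is new or still open speak of the compounds shown alone.

Compound 1, `Nc1scc(CN2CCN(c3cccnc3)CC2)c1C(=O)c1ccc(Cl)cc1`: 0%
Compound 2, `Nc1scc(CN2CCN(c3cccc(F)c3F)CC2)c1C(=O)c1ccc(Cl)cc1`: 0%

In an assay on CHO cells for displacement of a labelled ligand from adenosine receptor A3 (Homo sapiens), read by scintillation counting, with a stated time of 120 min, tested at 10 uM (on this read-out higher numbers stand for more inhibition at the one concentration tested (going by the name of the read-out) and lower numbers for less inhibition), compound 1 gives 0%, and compound 2 gives 0% in this assay. For the measured compounds named here, the one step measured so far, no change at the digits printed from compound 1 to compound 2 (within the scatter), shows that swapping the group on the ring amine nitrogen left the read-out flat, so compound 2 stands level with compound 1, both showing no measurable inhibition at the single concentration tested.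

Compound 3, `Nc1scc(CN2CCN(c3c(F)cc(F)cc3F)CC2)c1C(=O)c1ccc(Cl)cc1`, changes the same position once more: 2,4,6-trifluorophenyl in place of 2,3-difluorophenyl on an amine nitrogen in a ring. Going by the values given here, the only step that bears on this change is the one from compound 1 to compound 2, which showed no movement; nothing measured here suggests a fluorophenyl variant lifts the read-out. The expected step is therefore a number 2 percentage points higher from compound 2 to compound 3 (within the scatter). Compound 3 is estimated to give 2% in this assay, with a range from -8% to 15%.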

Compound 3, a percentage reported as inhibition, at one concentration (the size of the read-out at that concentration, not a potency): 0%
The estimate for compound 3 lay 2 percentage points above the measured number, within the range that was stated.
By their numbers in this assay, from the lowest: compounds 1, 2 and 3 (each within the scatter of the next).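

In this assay there is no change at the digits printed from compound 2 to compound 3 (within the scatter), and there is likewise no change at the digits printed from compound 1 to compound 3 (within the scatter). A single flat step could have been a quirk of one pair, but now three different aryl groups on this amine nitrogen, pyridin-3-yl, 2,3-difluorophenyl and 2,4,6-trifluorophenyl, all read the same, so changing the number of fluorines on the phenyl ring has not lifted the read-out here, and the read-out cannot rank these groups.

From the compounds shown here alone, it remains open whether any group at this position can produce inhibition at the one concentration tested, since all three groups here are six-membered aromatic rings. A carboxylic acid on the aryl group, or a simple methyl group in place of the aryl group, would test that question more sharply. Nothing available explains why the read-out stays flat.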